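Chlorophenyl Replaces Methylphenyl: Expectation for Compound 4

The source may hold more compounds than are shown below. What is called first, only, known or untested is meant among the compounds shown, and "the series" means these compounds.

Compound 3 `Cc1ccc(CSc2cc(Cl)c(C)cc2S(=O)(=O)/N=C(\N)n2nccc2-c2ccccc2)cc1` gives 14000 nM in a functional assay on HCT-116 cells (Homo sapiens) for cytotoxicity, read by MTT assay, with a stated time of 72 h (on this read-out higher numbers stand for weaker inhibition and lower numbers for stronger inhibition), the upper end of the three numbers shown, yet its steps from compound 1 `Cc1cc(S(=O)(=O)/N=C(\N)n2nccc2-c2ccccc2)c(SCc2ccccc2)cc1Cl`, which gives 12000 nM, and from compound 2 `Cc1cc(S(=O)(=O)/N=C(\N)n2nccc2-c2ccccc2)c(SCc2cccc3ccccc23)cc1Cl`, which gives 7000 nM, both stay within the scatter: a 1.2-fold higher number from compound 1 to compound 3 (0.07 log units; within the scatter) and a 2.0-fold higher number from compound 2 to compound 3 (0.30 log units; within the scatter). Compound 4 `Cc1cc(S(=O)(=O)/N=C(\N)n2nccc2-c2ccccc2)c(SCc2ccccc2Cl)cc1Cl` differs from compound 3 by 2-chlorophenyl in place of 4-methylphenyl on a saturated chain carbon bound to a sulfur. The two changes already made at this same carbon, a 1.7-fold lower number from compound 1 to compound 2 (0.23 log units; within the scatter) and a 2.0-fold higher number from compound 2 to compound 3 (0.30 log units; within the scatter), were each inside the scatter, so no step beyond the scatter is expected for this exchange either, in either direction. For compound 4 the expected step is a 1.3-fold lower number from compound 3 to compound 4 (0.10 log units; within the scatter), and its estimated value is 11000 nM with a range from 5000 nM to 25000 nM.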

Compound 4, half-maximal inhibitory concentration: 18000 nM
Compound 4: middle estimate off by 1.6-fold (0.21 log units), on the low side; measured number inside the range.
By their numbers in this assay, from the lowest: compounds 2, 1, 3 and 4 (each within the scatter of the next, the first and the last beyond it).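

In this assay, the exchanges on a saturated chain carbon bound to a sulfur now give the only step beyond the scatter among these compounds, though a modest one: a 2.6-fold higher number from compound 2 to compound 4 (0.41 log units; beyond the scatter), with 2-chlorophenyl in place of naphthalen-1-yl. The other two steps, a 1.3-fold higher number from compound 3 to compound 4 (0.11 log units; within the scatter) and a 1.5-fold higher number from compound 1 to compound 4 (0.18 log units; within the scatter), stay within the scatter, so 2-chlorophenyl cannot be told apart here from 4-methylphenyl or phenyl. Going by these compounds alone, nothing available explains the one larger step. On these data alone, whether an amine or a carboxylic acid at this carbon would shift the number further remains open.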